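Swapping a Methoxy for a Fluoro on Compound 1

The source may hold more compounds than are shown below. What is called first, only, known or untested is meant among the compounds shown, and "the series" means these compounds.

Three compounds from one series share a common core and have been tested in a functional assay on Right cardiac atrium for agonist activity at histamine H2 receptor (Cavia porcellus), with a stated time of 30 min, in the presence of a further agent that is not named here; on this read-out lower numbers stand for an effect already at smaller amounts and higher numbers for an effect only at larger amounts of compound. Compound 1, with the structure `COc1ccc(C(C)NC(=O)/N=C(\N)NCCCc2sc(N)nc2C)cc1`, gives 38 nM, the lowest of the three numbers. Compound 3, with the structure `Cc1nc(N)sc1CCCN/C(N)=N/C(=O)NC(c1ccccc1)c1ccccc1`, gives 39.8 nM, which lies within the scatter of compound 1. Compound 2, with the structure `Cc1nc(N)sc1CCCN/C(N)=N/C(=S)N[C@@H](C)c1ccccc1`, gives 224 nM, a number beyond the scatter above compound 1. For the measured compounds named here, these three compounds differ from one another in more than one place, so no single step between measured compounds can be read off.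

Compound 4, with the structure `Cc1nc(N)sc1CCCN/C(N)=N/C(=O)NC(C)c1ccc(F)cc1`, has not yet been measured. It differs from compound 1 by a fluoro in place of a methoxy on an aromatic carbon: fluoro in place of methoxy on an aromatic carbon. Going by the values given here, no measured pair isolates this change, so the expectation rests on how small the shift is. The step from compound 1 to compound 4 in this assay is expected to be small, a 1.3-fold higher number from compound 1 to compound 4 (0.12 log units; within the scatter), with no direction beyond the scatter. For compound 4 the estimated value is 50 nM, within a range from 20 nM to 125 nM.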

Compound 4, half-maximal effective concentration: 23.4 nM
Compound 4: the middle estimate sits 2.1-fold (0.33 log units) above what was measured; measured number inside the range.
By their numbers in this assay, from the lowest: compounds 4, 1 and 3 (each within the scatter of the next); then compound 2.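

For the compounds shown here, compound 1 and compound 4 differ only in the group on the six-membered aromatic ring, so this pair isolates a single position, which the earlier compounds could not do. Going from 4-methoxyphenyl to 4-fluorophenyl gives a 1.6-fold lower number from compound 1 to compound 4 (0.21 log units; within the scatter) in this assay and so stays within the usual scatter. At this position, then, a group of two heavy atoms with one hydrogen-bond acceptor can give way to a single fluorine atom with no acceptor, and the number does not move beyond that scatter.

Going by these compounds, only these two groups can be compared here, so it remains open whether a chloro, a hydroxyl, an amine or a carboxylic acid at the same position would also leave the number within the scatter. The compounds shown also leave open how a longer chain such as ethoxy would behave there. No measurement here accounts for the size of this step.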